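Working notes on the amine side-chain series

The source may report more compounds than this note shows. Statements on the series, on what has been measured and on what is new or still open speak of the compounds shown alone.

Measured so far:
compound 1, `N#Cc1cnc(NCc2cnccc2C(F)(F)F)cc1NC[C@H]1C[C@H](O)C1`: 700 nM
compound 2, `N#Cc1cnc(NCc2cnccc2C(F)(F)F)cc1NC[C@H]1CC[C@H](O)CC1`: 50 nM
compound 3, `N#Cc1cnc(NCc2cnccc2C(F)(F)F)cc1NCC1CCOCC1`: 400 nM

In an assay on isolated protein for inhibition of protein kinase C theta type (Homo sapiens), read by TR-FRET, with a stated time of 2 h (on this read-out lower numbers stand for stronger inhibition and higher numbers for weaker inhibition), compound 1 stands highest of the three numbers; compound 3 is nearest, with a 1.8-fold lower number from compound 1 to compound 3 (0.24 log units; within the scatter), and compound 2 furthest, with a 14-fold lower number from compound 1 to compound 2 (1.15 log units; beyond the scatter). Compound 4, `N#Cc1cnc(NCc2cnccc2C(F)(F)F)cc1NCCC1CCOCC1`, differs from compound 1 by (oxan-4-yl)methyl in place of 3-hydroxycyclobutyl on a saturated chain carbon bound to a nitrogen on an aromatic ring. Going by the values given here, the nearest guide is compound 3, which carries oxan-4-yl on the same carbon and gave a 1.8-fold lower number from compound 1 to compound 3 (0.24 log units; within the scatter); no measured pair shows what the added chain carbon does. The gain in a 14-fold lower number from compound 1 to compound 2 (1.15 log units; beyond the scatter) and the loss in an 8.0-fold higher number from compound 2 to compound 3 (0.90 log units; beyond the scatter) concern 4-hydroxycyclohexyl and do not bear directly here. The expected step is therefore a 1.4-fold lower number from compound 1 to compound 4 (0.15 log units; within the scatter), likely within the scatter. Compound 4 is estimated at 500 nM, range 150 nM to 1600 nM.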

Compound 4, half-maximal inhibitory concentration: 1200 nM
For compound 4 the middle estimate is 2.4-fold (0.38 log units) below the measured one; the measured number falls inside the stated range.
By their numbers in this assay, from the lowest: compound 2; then compounds 3, 1 and 4 (each within the scatter of the next, the first and the last beyond it).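

Replacing oxan-4-yl with (oxan-4-yl)methyl on the saturated chain carbon gives the first measured read on the added chain carbon, and it weakens inhibition (a 3.0-fold higher number from compound 3 to compound 4 (0.48 log units; beyond the scatter)). The exchange for 3-hydroxycyclobutyl stays within the scatter (a 1.7-fold higher number from compound 1 to compound 4 (0.23 log units; within the scatter)), whereas the exchange for 4-hydroxycyclohexyl is large (a 24-fold higher number from compound 2 to compound 4 (1.38 log units; beyond the scatter)). No evidence on hand accounts for these steps.

Open, as far as these compounds go, is whether (4-hydroxycyclohexyl)methyl in place of 4-hydroxycyclohexyl would give a comparable step. Also open, from the compounds shown here alone, is whether 4-aminocyclohexyl could stand in for 4-hydroxycyclohexyl at this position.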